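One Methyl Added to a Small Agonist

The source may report more compounds than this note shows. Statements on the series, on what has been measured and on what is new or still open speak of the compounds shown alone.

Going by the values given here, only two compounds have been tested so far in a functional assay on the whole organism for agonist activity, with Mus musculus as the target (on this read-out higher numbers stand for an effect only at larger amounts of compound and lower numbers for an effect already at smaller amounts), as a guide. Among the compounds with values here, compound 2 (`COC(=O)N(C)C(C)C#CCn1ccnc1`) gives 8 mg/kg and so holds the only true number at hand. For compound 1 (`CC(=O)N(C)C(C)C#CCn1cncc1C`) the reading of > 100 mg/kg is a limit and not a number.

Compound 3 (`COC(=O)N(C)C(C)C#CCn1cncc1C`) is compound 2 with a single change (methyl in place of hydrogen on an aromatic carbon), methyl in place of hydrogen on an aromatic carbon. Within the data shown here, no measured pair isolates this change, so any expectation here is loose. The direction expected is toward larger doses, by a step of moderate size that goes beyond the usual scatter. The estimated shift (a 3.1-fold higher number from compound 2 to compound 3 (0.49 log units; beyond the scatter)) carries wide uncertainty. In this assay compound 3 is estimated at 25 mg/kg (expected range 6 mg/kg to 100 mg/kg).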

Compound 3, dose for half-maximal effect: > 100 mg/kg
Compound 3: only a limit was reported; the forecaster's own chance of this, stated with the estimate: 25%; middle value at least 4.0-fold (0.60 log units) away from the limit.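

In this assay, a methyl that replaces the hydrogen on this aromatic carbon, next to the ring nitrogen and next to the ring atom that bears a large group, gives an at least 12-fold higher number from compound 2 to compound 3 (1.09 log units; beyond the scatter). Going by these compounds alone, this is the first pair of compounds to isolate the change, and it shows that one added carbon at this position is enough for a large step toward higher doses. That step is only a minimum, and its full size stays unknown because the reading for compound 3 is a limit and not a number: the limit of > 100 mg/kg in this assay, at which 2 of the 3 values shown sit.

The step between compound 1 and compound 3 cannot be read, as both ends are limits, so the choice between methoxy and methyl on the carbonyl carbon stays unresolved with this ring methyl in place. From the compounds shown here alone, how an ethyl group or a chlorine atom would read at this same aromatic carbon also remains open.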